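Hydroxyphenoxy Ether in Place of the Aminoethyl Terminus

The source may hold more compounds than are shown below. What is called first, only, known or untested is meant among the compounds shown, and "the series" means these compounds.

Compound 1, `CC(=O)NCCN(C)c1cccc(OCCCCN)c1`: 12900 nM
Compound 2, `CC(=O)NCCN(C)c1cccc(OCCCCCCN)c1`: 398 nM

In an assay on cells for displacement of a labelled ligand from melatonin receptor type 1B (Homo sapiens), using the Cheng-Prusoff equation, with a stated time of 90 min (a lower number here means a stronger inhibitor, a higher number a weaker inhibitor), compound 1 gives 12900 nM, while compound 2 gives 398 nM. For the measured compounds named here, compound 2 thus has the lowest of the two numbers, and its single neighbour, compound 1, is distant by a 32-fold lower number from compound 1 to compound 2 (1.51 log units; beyond the scatter). Compound 3, `CC(=O)NCCN(C)c1cccc(OCCCCOc2cccc(O)c2)c1`, is not yet measured. It differs from compound 2 by 3-hydroxyphenoxy in place of 2-aminoethyl on a saturated chain carbon, four bonds along the chain from an oxygen on an aromatic ring. Going by the values given here, the only measured step, from compound 1 to compound 2, concerns lengthening of the amino-bearing chain and bears only loosely on a change that removes the amine altogether and introduces an aromatic ether bearing a hydroxyl. Among the compounds with values here, no measured step tells how this assay responds to loss of the amine, so the expectation is broad. Compound 3 is expected to give a modest rise of a 2.0-fold higher number from compound 2 to compound 3 (0.30 log units; within the scatter), likely not beyond the scatter. Compound 3 is therefore estimated at 800 nM, within 150 nM to 4500 nM.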

Compound 3, inhibition constant: 603 nM
The estimate for compound 3 lay 1.3-fold (0.12 log units) above the measured number; the measured number falls inside the stated range.
By their numbers in this assay, from the lowest: compounds 2 and 3 (each within the scatter of the next); then compound 1.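

In this assay, 3-hydroxyphenoxy in place of 2-aminoethyl on this saturated chain carbon gives a 1.5-fold higher number from compound 2 to compound 3 (0.18 log units; within the scatter), a step within the scatter, so the number stays in the same range once the terminal amine is gone, which the earlier pair could not show. The same place read against the shorter amino chain gives a 21-fold lower number from compound 1 to compound 3 (1.33 log units; beyond the scatter), a large step beyond the scatter, so among these three compounds a low number does not depend on an amino group on the chain. Nothing at hand explains why such different groups give numbers within the scatter of each other.

On these data alone, how much the hydroxyl of the 3-hydroxyphenoxy group contributes stays open, and a plain phenoxy group on the same chain carbon would address it. Also open, as far as these compounds go, is what a carboxylic acid or a longer chain ending in 3-hydroxyphenoxy would give here.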